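A few compounds are considered here, and "the series" means these few. Any claim that something is new, unique, unknown or untested is made for them only; others in the source may bear on it.

Measured so far:
- compound 1, `O=C1CCCCN1c1ccc(C#Cc2c(F)cccc2F)cc1`: 6.4%
- compound 2, `Fc1cccc(F)c1C#Cc1cncc2ccccc12`: 16.5%

In a functional assay on LS174T cells (Homo sapiens) for inhibition, with a stated time of 4 days, tested at 1 uM (on this read-out lower numbers stand for a weaker effect and higher numbers for a stronger effect at the one concentration tested), compound 2 gives 16.5%. Compound 2 stands highest of the two numbers shown; the nearest is compound 1, which in this assay gives 6.4%, a step that lies beyond the usual scatter. Within the data shown here, compound 1 and compound 2 share the diarylacetylene motif but differ in their aryl partner, and no single-point step between them is counted.

Compound 3, `CNc1ncc(C#Cc2c(F)cccc2F)c2ccccc12`, is not yet measured in this assay. It differs from compound 2 in one place: methylamino in place of hydrogen on an aromatic carbon. Among the measured compounds shown here, no measured step of this kind exists, so the expectation rests only on the two numbers above and the single change. Inhibition is expected to remain modest and, if it moves, to move upward rather than downward, since the group entering is a methylamino with a hydrogen-bond donor and acceptor; the step from compound 2 to compound 3 is estimated as a number 13.5 percentage points higher from compound 2 to compound 3 (beyond the scatter), with a wide range. For compound 3 the expected value in this assay is 30%, estimated between 5% and 65%.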

Compound 3, a percentage reported as inhibition, at one concentration (the size of the read-out at that concentration, not a potency): 99.8%
Compound 3: middle estimate off by 69.8 percentage points, on the low side; measured number outside the range, above it.
By their numbers in this assay, from the lowest: compound 1; then compound 2; then compound 3.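

In this assay, the aromatic carbon next to the ring nitrogen proves to be a highly sensitive place: methylamino in place of hydrogen gives a number 83.3 percentage points higher from compound 2 to compound 3 (beyond the scatter), a large step that compound 2, with hydrogen there, could not reveal on its own. This is a single change at a single concentration, so it shows the size of the read-out and not a potency. Nothing available here bears on the origin of this step.

As far as these compounds go, it remains open whether the gain is specific to methylamino: a primary amine, dimethylamino or ethylamino at the same place would test this. Also open, from the compounds shown here alone, is whether methylamino at this place would have a similar effect with other groups on the far side of the acetylene, and how compound 3 behaves at other concentrations.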